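Ethyl to Cyclohexyl on a Weakly Antiproliferative Core

This account rests on a few compounds, and the source may have more. Where it says the series, first, only, none or still open, it means among the compounds named here.

Compound 1 `C[C@H]1CC(Cl)=C([Si](C)(C)C)[C@@H](C2CCCCC2)O1`: 32000 nM
Compound 2 `CC[C@H]1CC(Cl)=C([Si](C)(C)C)[C@@H](C2CCCCC2)O1`: 35000 nM

Of the compounds shown here, two have been measured in a functional assay on A2780 cells (Homo sapiens) for antiproliferative activity; a lower number here means a stronger inhibitor of growth, a higher number a weaker inhibitor of growth. Compound 1 `C[C@H]1CC(Cl)=C([Si](C)(C)C)[C@@H](C2CCCCC2)O1` gives 32000 nM in this assay, and compound 2 `CC[C@H]1CC(Cl)=C([Si](C)(C)C)[C@@H](C2CCCCC2)O1` gives 35000 nM. Going by the values given here, the only step between them, a 1.1-fold higher number from compound 1 to compound 2 (0.04 log units; within the scatter), lies within the scatter, so compound 2 cannot be told apart from compound 1 on these numbers; both sit at weak inhibition of growth.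

Compound 3 `C[Si](C)(C)C1=C(Cl)C[C@H](C2CCCCC2)O[C@@H]1C1CCCCC1` has not been measured. It differs from compound 2 by cyclohexyl in place of ethyl on a saturated ring carbon. Among the compounds with values here, only one measured step bears on this, and only loosely: a 1.1-fold higher number from compound 1 to compound 2 (0.04 log units; within the scatter) shows that adding a methyl to the chain on this carbon left this assay unmoved. Within the data shown here, no measured step shows a cyclohexyl entering at this place, so the evidence is thin. On what is shown, compound 3 is expected to stay close to compound 2, with the step of no change at the digits printed from compound 2 to compound 3 (within the scatter) estimated as none beyond the scatter. Compound 3 is therefore estimated at 35000 nM in this assay, with a range from 10000 nM to 120000 nM.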

Compound 3, concentration for total growth inhibition: 46000 nM
The estimate for compound 3 lay 1.3-fold (0.12 log units) below the measured number, and the stated range covers the measured number.
By their numbers in this assay, from the lowest: compounds 1, 2 and 3 (each within the scatter of the next).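

In this assay the exchange of ethyl for cyclohexyl on this saturated ring carbon next to the ring oxygen comes out as a 1.3-fold higher number from compound 2 to compound 3 (0.12 log units; within the scatter) and so does not separate the two compounds. Starting from methyl, the same cyclohexyl gives a 1.4-fold higher number from compound 1 to compound 3 (0.16 log units; within the scatter) and thus shows that a six-membered ring of carbon only can stand at this place, where the earlier pair differed only by one chain carbon, without a change beyond the scatter; none of the three compounds goes against this flat picture. No supporting measurement is available to explain why the number holds across methyl, ethyl and cyclohexyl. The compounds shown leave open whether a group of another kind on this carbon, such as an amine or a carboxylic acid, would move the number, since all three substituents here are plain hydrocarbon groups. They also leave open whether replacing the chloro group on the ring with a hydroxyl, or changing the cyclohexyl group on the other ring carbon, would lift the shared core out of its weak range.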